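The source may report more compounds than this note shows. Statements on the series, on what has been measured and on what is new or still open speak of the compounds shown alone.

Compound 1 `CNS(=O)(=O)c1ccccc1Nc1cc(-c2ccc3ccn(C)c3c2)c2nccnc2c1`: 104 nM
Compound 2 `CN(Cc1cncnc1)S(=O)(=O)c1ccccc1Nc1cc(-c2ccc3ccn(C)c3c2)c2nccnc2c1`: 62 nM
Compound 3 `Cn1cc(NC(=O)c2ccncc2Nc2cc(-c3ccc4ccn(C)c4c3)c3nccnc3c2)cn1`: 33 nM

All three were measured in an assay for inhibition of 6-phosphofructo-2-kinase/fructose-2,6-bisphosphatase 3 (Homo sapiens), read by ADP-Glo, with a stated time of 2 h; a higher number here means a weaker inhibitor, a lower number a stronger inhibitor. Compound 3 gives the lowest of the three numbers, but its gap to compound 2 is within the scatter, so the two cannot be ranked against each other; only its gap to compound 1 is beyond the scatter.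

Compound 4 `CC(=O)N1CCCC(NC(=O)c2ccncc2Nc2cc(-c3ccc4ccn(C)c4c3)c3nccnc3c2)C1` is the next compound and differs from compound 3 in one place: 1-acetylpiperidin-3-yl in place of 1-methyl-1H-pyrazol-4-yl on an amide-type nitrogen. Among the measured compounds shown here, no measured pair changes this part of the molecule. For the measured compounds named here, the single step that has been measured, a 1.7-fold lower number from compound 1 to compound 2 (0.22 log units; within the scatter), sits at a sulfonamide nitrogen in a different part of the structure and lies within the scatter; it shows only that a substituent on that nitrogen did little. Compound 3 and compound 2 differ in several places at once, so their two values cannot be read as one step either.

With nothing directly comparable, the expectation for this assay is no step beyond the scatter, with the swap from an aromatic to a non-aromatic ring leaving room for a modest weakening. The estimated step is a 1.5-fold higher number from compound 3 to compound 4 (0.18 log units; within the scatter). Compound 4 is therefore expected to give about 50 nM, within a range from 15 nM to 160 nM.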

Compound 4, half-maximal inhibitory concentration: 11 nM
For compound 4 the middle estimate is 4.5-fold (0.66 log units) above the measured one, outside the stated range (below it).
By their numbers in this assay, from the lowest: compound 4; then compounds 3, 2 and 1 (each within the scatter of the next, the first and the last beyond it).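

In this assay, among the compounds shown here, the amide-type nitrogen proves to be a place where the substituent can matter: 1-acetylpiperidin-3-yl in place of 1-methyl-1H-pyrazol-4-yl gives a 3.0-fold lower number from compound 3 to compound 4 (0.48 log units; beyond the scatter), the only step in this set that lies beyond the scatter. The result also shows that, at least in this pair, a five-membered aromatic ring on this nitrogen is not needed to keep the number low, as a six-membered non-aromatic ring carrying an acetyl group and more heavy atoms gives the lower value, although ring type, size and the added carbonyl all change together in this single swap. No measurement at hand explains the difference.

The compounds shown leave open whether the acetyl group or the piperidine ring accounts for the step, a question that a plain piperidin-3-yl with hydrogen on its ring nitrogen, a 1-methylpiperidin-3-yl or a cyclohexyl ring could help to answer. Also open, on these data alone, is whether the point of attachment matters, as a 1-acetylpiperidin-4-yl group on the same nitrogen would show.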